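The source may report more compounds than this note shows. Statements on the series, on what has been measured and on what is new or still open speak of the compounds shown alone.

Compound 1 `COc1ccc(C)cc1N1C(=O)CSC1c1cccc(C(=O)NCCCCc2ccccc2)c1` carries a 2-methoxy-5-methylphenyl on an amide-type nitrogen in a ring of the shared core. In a functional assay on U2OS cells (Homo sapiens) for inhibition, read by CCK-8 assay, with a stated time of 72 h, tested at 1 uM (on this read-out lower numbers stand for less inhibition and higher numbers for more inhibition at the one concentration tested (going by the name of the read-out)), compound 1 gives 30%. Two other compounds keep the same core and differ from compound 1 only in the group on that nitrogen. Compound 2 `O=C(NCCCCc1ccccc1)c1cccc(C2SCC(=O)N2c2cccc(F)c2)c1` gives 39% in this assay, and compound 3 `CC(F)(F)c1cccc(N2C(=O)CSC2c2cccc(C(=O)NCCCCc3ccccc3)c2)c1` gives 24%. Compound 1 therefore stands second highest of the three numbers, with compound 3 as its nearest neighbour and compound 2 as its furthest. Measured from it, a number 9 percentage points higher from compound 1 to compound 2 (within the scatter) and a number 6 percentage points lower from compound 1 to compound 3 (within the scatter). Among the measured compounds shown here, the one step that lies beyond the scatter runs between the two neighbours: a number 15 percentage points lower from compound 2 to compound 3 (beyond the scatter).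

Compound 4 `COc1ccc(N2C(=O)CSC2c2cccc(C(=O)NCCCCc3ccccc3)c2)c(OC)c1` has not been measured. It differs from compound 1 by 2,4-dimethoxyphenyl in place of 2-methoxy-5-methylphenyl on an amide-type nitrogen in a ring. The two measured steps that bear on this change, both of which swap the group on the same amide-type nitrogen, stayed within the scatter. On that basis the step of no change at the digits printed from compound 1 to compound 4 (within the scatter) is expected to be small, with no clear direction beyond the scatter. In this assay compound 4 is accordingly estimated at 30%, with a likely range from 17% to 43%.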

Compound 4, a percentage reported as inhibition, at one concentration (the size of the read-out at that concentration, not a potency): 37%
Compound 4: the middle estimate sits 7 percentage points below what was measured; low and high end bracket the measured number.
By their numbers in this assay, from the lowest: compounds 3, 1, 4 and 2 (each within the scatter of the next, the first and the last beyond it).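

Placing 2,4-dimethoxyphenyl on the amide-type nitrogen gives a number 7 percentage points higher from compound 1 to compound 4 (within the scatter), so a third replacement for the 2-methoxy-5-methylphenyl group also stays within the scatter of compound 1. What is new is a second separation from compound 3: the measured step is a number 13 percentage points higher from compound 3 to compound 4 (beyond the scatter), and the comparison with the fluorinated compound gives a number 2 percentage points lower from compound 2 to compound 4 (within the scatter), so compounds 2 and 4 both stand apart from compound 3 in this assay, while compound 1 does not. No supporting measurement is available to explain these differences between groups at this position.

The compounds shown all carry a substituted phenyl ring on this nitrogen, which leaves open whether a pyridine ring, a cyclohexyl ring or an open carbon chain there would keep the number in this same narrow band or move it well outside. From the compounds shown here alone, each number also comes from a single concentration, so how these compounds would compare across a range of concentrations remains unknown.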